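Two thiazole amides and their tolerance by liver cells

This account rests on a few compounds, and the source may have more. Where it says the series, first, only, none or still open, it means among the compounds named here.

The study compares tolerance of compounds in an ADME assay on HepG2 2.2.15 cells (Homo sapiens) for cytotoxicity; a higher number here means that more compound is tolerated, a lower number that less compound is tolerated. Compound 1 `O=C(CCCCC(=O)Nc1ncc(Cc2ccc(F)cc2)s1)Nc1ncc(Cc2ccc(F)cc2)s1` is a symmetric bis-amide; in this assay compound 1 gives > 50000 nM, which is a limit of the assay and not a number. Compound 2 `COCCNc1ncc(C(Oc2ccc3cc(Br)ccc3c2)c2ccc(Cl)cc2)s1` carries a single aminothiazole core; in this assay compound 2 is reported as "not toxic" (no number reported), so no single number stands for it. Of the two values shown, one sits at the limit of > 50000 nM in this assay, at which 1 of the 2 values shown sits, and the other is given only in words, so neither compound places a number on the scale.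

Compound 3 `O=C(Nc1ncc(C(Oc2ccc3cc(Br)ccc3c2)c2ccc(Cl)cc2)s1)c1ccc(F)cc1` is the untested partner of compound 2. The difference between the two is (4-fluorophenyl)carbonyl in place of 2-methoxyethyl on a nitrogen on an aromatic ring. Within the data shown here, since no measured step connects two compounds here, the size of the step cannot be read from the data; given that both measured compounds show no toxicity up to the range probed, the step from compound 2 to compound 3 in this assay is expected to stay within the scatter, with no direction favoured. For compound 3 in this assay the expected value is 50000 nM, in a range from 15000 nM to 100000 nM, most likely again reported only as a limit.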

Compound 3, half-maximal cytotoxic concentration: "not toxic" (no number reported)
The entry for compound 3 holds no number, and the estimate cannot be compared.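

Among these compounds, compound 2 and compound 3 are both reported only in words, as "not toxic", so no step from one to the other can be read. The compounds shown leave open at what concentration in this assay any of them would stop being tolerated, and whether the change between compound 2 and compound 3 alters that concentration.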